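The source may hold more compounds than are shown below. What is called first, only, known or untested is meant among the compounds shown, and "the series" means these compounds.

Among the measured compounds shown here, compound 2 `COc1cc(-c2nnc(SCC(=O)c3ccc(Br)cc3)n2N2C(=O)c3ccccc3C2=O)cc(OC)c1OC` is the only compound here with a number rather than a limit in a functional assay on HepG2 cells (Homo sapiens) for cytotoxicity, read by MTT assay, with a stated time of 48 h; on this read-out higher numbers stand for weaker inhibition and lower numbers for stronger inhibition: in this assay compound 2 gives 27700 nM. Compound 1 `COc1cc(-c2nnc(SC)n2N2C(=O)c3ccccc3C2=O)cc(OC)c1OC` reaches only the limit of this assay, at which compound 1 gives > 200000 nM (the limit of > 200000 nM in this assay, at which 1 of the 2 values shown sits). Compound 3 `COc1cc(-c2nnc(SCC(=O)c3ccc(F)c(F)c3)n2N2C(=O)c3ccccc3C2=O)cc(OC)c1OC` differs from compound 2 by 3,4-difluorophenyl in place of 4-bromophenyl on a carbonyl carbon. For the measured compounds named here, the single measured step, an at least 7.2-fold lower number from compound 1 to compound 2 (0.85 log units; beyond the scatter), concerns the addition of the whole (4-bromophenyl)carbonyl group onto the chain carbon bound to sulfur, not an exchange of one halogenated ring for another, so no measured step bears directly on the change toward compound 3. In the absence of such a comparison, compound 3 is expected to move by a 1.1-fold higher number from compound 2 to compound 3 (0.03 log units; within the scatter), a step that is not expected to go beyond the scatter. Compound 3 is therefore estimated at 30000 nM, with a range from 10000 nM to 90000 nM.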

Compound 3, half-maximal inhibitory concentration: > 200000 nM
Compound 3 ended at the assay's limit; the forecaster's own chance of this, stated with the estimate: 15%; at least 6.6-fold (0.82 log units) between middle value and limit.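

Putting 3,4-difluorophenyl in place of 4-bromophenyl on the carbonyl carbon moves the result in this assay by an at least 7.2-fold higher number from compound 2 to compound 3 (0.85 log units; beyond the scatter). The measurable value of compound 2 therefore does not follow from the carbonyl-bearing chain on sulfur alone, as the ring on that carbonyl carbon also matters here, and this position does not treat these two halogenated phenyl groups alike. The step from compound 1 to compound 3 cannot be read, and compound 3 gives only a limit: the limit of > 200000 nM in this assay, at which 2 of the 3 values shown sit.

The compounds shown leave open whether the bromine atom itself or the overall ring substitution sets this difference. A 4-chlorophenyl, 4-fluorophenyl or unsubstituted phenyl group on the same carbonyl carbon would help separate these possibilities.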